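Ester Variation at the Chain End of the Shared Core

The compounds below may be only part of what the source reports. "The series", "measured", "known", "first", "only" and "open" are said of these compounds alone.

Compound 1 `CC1=C(C(=O)OCc2ccccc2)C(c2ccc(Cl)cc2Cl)NC(=O)N1CCCCC(=O)O` gives > 100000 nM in an ADME assay on MCF7 cells (Homo sapiens) for cytotoxicity, read by CellTiter-Glo, with a stated time of 24 h; a lower number here means a stronger inhibitor of growth, a higher number a weaker inhibitor of growth.
Compound 2 `CC1=C(C(=O)OCc2ccccc2)C(c2ccc(Cl)cc2Cl)NC(=O)N1CCCC(=O)OCc1ccccc1` gives > 100000 nM in this assay.
Compound 3 `C/C=C/COC(=O)CCCN1C(=O)NC(c2ccc(Cl)cc2Cl)C(C(=O)OCc2ccccc2)=C1C` gives > 100000 nM in this assay.

Each of these three values is a limit of this assay, not a number, and compound 3 therefore stands at the same limit as the others, with no place of its own among them; this is the situation described by the limit of > 100000 nM in this assay, at which 3 of the 3 values shown sit. The measured steps are accordingly unreadable: a step that the two limits leave unreadable from compound 1 to compound 2, a step that the two limits leave unreadable from compound 1 to compound 3 and a step that the two limits leave unreadable from compound 2 to compound 3 all connect two limits and give no size.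

Compound 4 `COCCOC(=O)CCCN1C(=O)NC(c2ccc(Cl)cc2Cl)C(C(=O)OCc2ccccc2)=C1C` carries the change (methoxymethyl in place of prop-1-en-1-yl on a saturated chain carbon bound to an oxygen next to a carbonyl group). Within the data shown here, the steps that bear on it are the three just named, all of which exchange one ester or chain end for another without leaving the limit. The account therefore expects no step beyond the scatter in this assay, so that the step from compound 3 to compound 4 is estimated as a step that the limit leaves unreadable from compound 3 to compound 4. Compound 4 is expected to give about 200000 nM, within the range 100000 nM to 1000000 nM, most likely reported again only as a limit.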

Compound 4, concentration for 50% growth inhibition: > 100000 nM
Compound 4 gave a limit, no number; the forecaster's own chance of this, stated with the estimate: 90%; the middle value does not contradict the limit.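

In this assay compound 4 gives > 100000 nM as a limit, not a number. No step from compound 1, compound 2 or compound 3 to compound 4 can therefore be read: the limit of > 100000 nM in this assay, at which 4 of the 4 values shown sit.

In this assay the compounds shown leave open what number any of the four would give, and whether any chain-end ester on the shared core would give a readable value.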